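The source may report more compounds than this note shows. Statements on the series, on what has been measured and on what is new or still open speak of the compounds shown alone.

Within the data shown here, in a functional assay on A549 cells (Homo sapiens) for inhibition, read by MTT assay, with a stated time of 72 h (a higher number here means a weaker inhibitor, a lower number a stronger inhibitor), compound 2 `Oc1ccc(-c2nnc(SCCCN3CCN(c4nc5ccccc5o4)CC3)o2)cc1` gives 181000 nM, the highest of the two numbers so far, while compound 1 `Fc1ccc(-c2nnc(SCCCN3CCN(c4nc5ccccc5o4)CC3)o2)cc1` gives 75700 nM. Compound 3 `c1ccc(-c2nnc(SCCCN3CCN(c4nc5ccccc5o4)CC3)o2)cc1` has hydrogen in place of hydroxy on an aromatic carbon, para to a large group: hydrogen in place of hydroxy on an aromatic carbon. Among the measured compounds shown here, the only measured step at this place is modest: a 2.4-fold higher number from compound 1 to compound 2 (0.38 log units; beyond the scatter), with hydroxy in place of fluoro. Losing the hydroxy is therefore expected to lower the number by a similarly modest amount, and the expected change is a 2.1-fold lower number from compound 2 to compound 3 (0.33 log units; beyond the scatter). For compound 3 the estimated value is 85000 nM, within a range of 40000 nM to 170000 nM.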

Compound 3, half-maximal inhibitory concentration: 108000 nM
Estimate against measurement, compound 3: 1.3-fold (0.10 log units) below; the range from low to high includes it.
By their numbers in this assay, from the lowest: compounds 1, 3 and 2 (each within the scatter of the next, the first and the last beyond it).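

Set against hydrogen in this assay, neither substituent stands apart at this position: hydrogen in place of hydroxy gives a 1.7-fold lower number from compound 2 to compound 3 (0.22 log units; within the scatter), and hydrogen in place of fluoro gives a 1.4-fold higher number from compound 1 to compound 3 (0.15 log units; within the scatter). Each substituent is thus indistinguishable from plain hydrogen, and only compound 1 and compound 2 differ from each other beyond the scatter. Nothing measured here explains these numbers. As far as these compounds go, what stays open is whether an amine or a carboxylic acid on this aromatic carbon would shift the number clearly away from that of compound 3.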